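Bromo in Place of Methyl: An Expectation for Compound 4

This account rests on a few compounds, and the source may have more. Where it says the series, first, only, none or still open, it means among the compounds named here.

Three compounds sharing one core were tested in a functional assay on WiDr cells (Homo sapiens) for inhibition, read by sulforhodamine B assay, with a stated time of 48 h; a lower number here means a stronger inhibitor of growth, a higher number a weaker inhibitor of growth. Compound 1 `COC(=O)[C@@]1(C)CCC=C2[C@@H]1CC[C@@H](C)[C@]2(C)Cc1c[nH]c2c(C)cccc12` gives 26000 nM. Compound 2 `COC(=O)[C@@]1(C)CCC=C2[C@@H]1CC[C@@H](C)[C@]2(C)Cc1c[nH]c2c(Br)cccc12` differs from it by bromo in place of methyl on an aromatic carbon and gives 32000 nM; the step of a 1.2-fold higher number from compound 1 to compound 2 (0.09 log units; within the scatter) is small. Compound 3 `COC(=O)[C@@]1(C)CCC=C2[C@@H]1CC[C@@H](C)[C@]2(C)Cc1c(C)[nH]c2c(C)cccc12` differs from compound 1 by methyl in place of hydrogen on an aromatic carbon, and in this assay compound 3 gives 21000 nM; here too the step of a 1.2-fold lower number from compound 1 to compound 3 (0.09 log units; within the scatter) is slight. All three values lie close together, and none of the pairs is separated beyond the usual scatter, so no ordering among them can be claimed.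

Compound 4 `COC(=O)[C@@]1(C)CCC=C2[C@@H]1CC[C@@H](C)[C@]2(C)Cc1c(C)[nH]c2c(Br)cccc12` has not yet been measured. It differs from compound 3 by bromo in place of methyl on an aromatic carbon. Within the data shown here, this is the same change as the one from compound 1 to compound 2, at a place described in the same words, and so the one measured example of it is the only guide available.

Among the measured compounds shown here, for compound 4 the step is expected to be a 1.2-fold higher number from compound 3 to compound 4 (0.08 log units; within the scatter), because the only measured instance of this change, a 1.2-fold higher number from compound 1 to compound 2 (0.09 log units; within the scatter), was within the scatter. On that basis compound 4 is estimated in this assay at 25000 nM, with a range from 12000 nM to 50000 nM allowing for the usual spread of such measurements.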

Compound 4, concentration for 50% growth inhibition: 38000 nM
Beside the measured number, compound 4's estimate is 1.5-fold (0.18 log units) below it; the measured number falls inside the stated range.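

In this assay, bromo in place of methyl on an aromatic carbon gives a 1.8-fold higher number from compound 3 to compound 4 (0.26 log units; within the scatter), and this second instance does not set the change apart from the first, so on these two cores it carries over without a detectable difference: the same change on two cores in this assay, a 1.2-fold higher number (0.09 log units; within the scatter) from compound 1 to compound 2 and a 1.8-fold higher number (0.26 log units; within the scatter) from compound 3 to compound 4, 1.5-fold (0.17 log units) apart, within the scatter of two such steps

The other change in this set of four, methyl in place of hydrogen on an aromatic carbon, gives a 1.2-fold higher number from compound 2 to compound 4 (0.07 log units; within the scatter), and it agrees with its earlier instance in the same way: the same change on two cores in this assay, a 1.2-fold lower number (0.09 log units; within the scatter) from compound 1 to compound 3 and a 1.2-fold higher number (0.07 log units; within the scatter) from compound 2 to compound 4, 1.5-fold (0.17 log units) apart, within the scatter of two such steps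

This does not show that either change has a real effect on growth inhibition, since every one of these steps lies within the scatter, and two pairs for each change, all with small steps, cannot establish a rule that would hold beyond compounds 1 to 4.

On these data alone, it stays open whether a different group on the same aromatic carbons, such as an amine, a carboxylic acid or a longer chain, would give a step beyond the scatter. As far as these compounds go, it also stays open whether bromo in place of methyl would behave the same way on a core other than these two.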